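The source may hold more compounds than are shown below. What is called first, only, known or untested is meant among the compounds shown, and "the series" means these compounds.

Working notes on the series. In a functional assay on isolated protein for inhibition of Glucose-dependent insulinotropic receptor (Rattus norvegicus), read by HTRF and cAMP accumulation (a lower number here means a smaller maximal response, a higher number a larger maximal response), compound 2 `Cc1nc(S(C)(=O)=O)ccc1Oc1ncnc(OC2CCN(C(=O)SC3CC3)CC2)c1F` gives 80% and compound 1 `Cc1nc(S(C)(=O)=O)ccc1Oc1ncnc(OC2CCN(C(=O)OC3CCC3)CC2)c1F` gives 81%, the two numbers within the scatter of each other. For the measured compounds named here, the one measured step, a number 1 percentage points lower from compound 1 to compound 2 (within the scatter), exchanged the group on the carbonyl carbon without moving the maximal response beyond the scatter. Compound 3 `Cc1nc(S(C)(=O)=O)ccc1Oc1ncnc(OC2CCN(C(=O)SC3(C)CC3)CC2)c1F` carries methyl in place of hydrogen on a saturated ring carbon, a change at the group that this measured step also altered, so the step bears on it. Given that a number 1 percentage points lower from compound 1 to compound 2 (within the scatter) stayed within the scatter, no step beyond the scatter is expected in this assay, the estimated step being no change at the digits printed from compound 2 to compound 3 (within the scatter). Compound 3 is therefore expected to give 80%, in the range 70% to 90%.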

Compound 3, largest response reached (reported as efficacy), in percent of the reference or control that the assay uses: 77%
Beside the measured number, compound 3's estimate is 3 percentage points above it, and the stated range covers the measured number.
By their numbers in this assay, from the lowest: compounds 3, 2 and 1 (each within the scatter of the next).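

In this assay, methyl in place of hydrogen on a saturated ring carbon gives a number 3 percentage points lower from compound 2 to compound 3 (within the scatter), so this ring carbon accepts the methyl with no reading beyond the scatter. The wider exchange on the carbonyl carbon gives a number 4 percentage points lower from compound 1 to compound 3 (within the scatter), which extends the flat picture from cyclopropyl to 1-methylcyclopropyl. No measurement at hand gives a cause for these readings. Open, on these data alone, is whether ethyl, trifluoromethyl or an amine on this same ring carbon would move the maximal response beyond the scatter.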